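The source may hold more compounds than are shown below. What is called first, only, known or untested is meant among the compounds shown, and "the series" means these compounds.

In an assay for inhibition of mitogen-activated protein kinase kinase kinase 14 (Homo sapiens), read by luminescence and ADP-Glo, with a stated time of 120 min, in the presence of a further agent that is not named here (on this read-out lower numbers stand for stronger inhibition and higher numbers for weaker inhibition), compound 1 `CN(C)c1ccc(C#CC(C)(O)c2nccs2)cc1Nc1ncnc2[nH]ccc12` gives 22.5 nM, and compound 2 `CCN1CCN(c2ccc(C#CC(C)(O)c3nccs3)cc2Nc2ncnc3[nH]ccc23)CC1` gives 34.5 nM. On these two numbers compound 2 stands with the higher value, though the change a 1.5-fold higher number from compound 1 to compound 2 (0.19 log units; within the scatter) stays inside the scatter, so the two compounds cannot be told apart. Compound 3 `CC(O)(C#Cc1ccc(N2CCN(S(=O)(=O)C3CC3)CC2)c(Nc2ncnc3[nH]ccc23)c1)c1nccs1` has not yet been measured. It differs from compound 2 in one place: cyclopropylsulfonyl in place of ethyl on an amine nitrogen in a ring. Within the data shown here, the only measured step that bears on this position is the one from compound 1 to compound 2, where a change on the same side of the shared core moved this assay hardly at all. That gives some reason to expect that compound 3 will also stay close to compound 2, but no measured pair shows a sulfonyl group entering there, so the range must be kept wide. Compound 3 is therefore expected to show a step of about a 1.2-fold higher number from compound 2 to compound 3 (0.06 log units; within the scatter) in this assay. Compound 3 is estimated at 40 nM, with a range from 15 nM to 120 nM.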

Compound 3, half-maximal inhibitory concentration: 16.2 nM
For compound 3 the middle estimate is 2.5-fold (0.39 log units) above the measured one; the measured number falls inside the stated range.
By their numbers in this assay, from the lowest: compounds 3, 1 and 2 (each within the scatter of the next, the first and the last beyond it).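

Among these compounds, at this position, on an amine nitrogen in a ring, the larger cyclopropylsulfonyl group is accepted in place of ethyl without any loss in this assay: the step of a 2.1-fold lower number from compound 2 to compound 3 (0.33 log units; beyond the scatter) is modest, but it is the first here to lie beyond the scatter. Set against the dimethylamino group, the full 4-(cyclopropylsulfonyl)piperazin-1-yl group gives a step of a 1.4-fold lower number from compound 1 to compound 3 (0.14 log units; within the scatter), so these two compounds cannot be told apart. No supporting measurement is available to explain what lies behind the step from ethyl to cyclopropylsulfonyl.

From the compounds shown here alone, it remains open whether the sulfonyl or the cyclopropyl part accounts for that step. A plain cyclopropyl, a methylsulfonyl or a cyclopropylcarbonyl group on the same nitrogen would separate the two parts.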